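The source may hold more compounds than are shown below. What is called first, only, known or untested is meant among the compounds shown, and "the series" means these compounds.

In a functional assay on HepG2 cells (Homo sapiens) for antiproliferative activity, read by CCK-8 assay, with a stated time of 48 h (on this read-out higher numbers stand for weaker inhibition and lower numbers for stronger inhibition), compound 1 `COc1ccc(/C=C\c2cc(OC)c(OC)c(OC)c2)cc1OCc1ccc(CN2CCCCC2C(=O)O)cc1` gives 3100 nM and compound 2 `COc1ccc(/C=C\c2cc(OC)c(OC)c(OC)c2)cc1OCc1ccc(CN2CC[C@H](C(=O)O)C2)cc1` gives 6400 nM. Compound 3 `COc1ccc(/C=C\c2cc(OC)c(OC)c(OC)c2)cc1OCc1ccc(CN2CC(C(=O)O)C2)cc1` stands only at a limit of the assay, > 10000 nM, and not at a number. Compound 4 `COc1ccc(/C=C\c2cc(OC)c(OC)c(OC)c2)cc1OCc1ccc(CNCCN(C)C)cc1` differs from it by (2-(dimethylamino)ethyl)amino in place of 3-carboxyazetidin-1-yl on a saturated chain carbon bound to an aromatic carbon, with (2-(dimethylamino)ethyl)amino in place of 3-carboxyazetidin-1-yl. The measured steps at this same place are a 2.1-fold higher number from compound 1 to compound 2 (0.31 log units; beyond the scatter) and an at least 3.2-fold higher number from compound 1 to compound 3 (0.50 log units; beyond the scatter), both modest, and an at least 1.5-fold higher number from compound 2 to compound 3 (0.19 log units; that floor lies within the scatter), whose floor lies within the scatter. All three swap one carboxy ring for another, so they are only a rough guide. Given compound 1 at 3100 nM, a modest move towards stronger inhibition is expected in this assay. The expected step is an at least 4.0-fold lower number from compound 3 to compound 4 (0.60 log units; beyond the scatter). Compound 4 is estimated at 2500 nM, within a range of 500 nM to 10000 nM.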

Compound 4, half-maximal inhibitory concentration: 4400 nM
Beside the measured number, compound 4's estimate is 1.8-fold (0.25 log units) below it; the measured number falls inside the stated range.
By their numbers in this assay, from the lowest: compounds 1, 4 and 2 (each within the scatter of the next, the first and the last beyond it). At a limit, above all of these: compound 3.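

In this assay, the open-chain (2-(dimethylamino)ethyl)amino, with no ring and no carboxy group, gives a measurable value on a saturated chain carbon bound to an aromatic carbon, an at least 2.2-fold lower number from compound 3 to compound 4 (0.35 log units; beyond the scatter). Compound 3 stands at a limit and not at a number, so that step is only a floor: the limit of > 10000 nM in this assay, at which 1 of the 4 values shown sits. The two carboxy rings with numbers are not separated from the open chain, a 1.5-fold lower number from compound 2 to compound 4 (0.16 log units; within the scatter) and a 1.4-fold higher number from compound 1 to compound 4 (0.15 log units; within the scatter), so a carboxy ring is not required here for activity in this range. The compounds shown leave open what a piperidine without the carboxylic acid would give. They also leave open how a longer chain than (2-(dimethylamino)ethyl)amino would read.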